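This account rests on a few compounds, and the source may have more. Where it says the series, first, only, none or still open, it means among the compounds named here.

Measured so far in an assay on cells for inhibition of MAP kinase-interacting serine/threonine-protein kinase 1 (Homo sapiens), read by mobility shift assay, with stated times of 10 min and 60 min, in the presence of a further agent that is not named here; on this read-out higher numbers stand for weaker inhibition and lower numbers for stronger inhibition:
compound 1, `NC(=O)c1ccc(-c2cccnc2)cc1OC1CCNCC1`, gives 1100 nM
compound 2, `NC(=O)c1ccc(-c2cccnc2)cc1Cl`, gives 11000 nM

Compound 2 stands at the higher of the two numbers shown. Its nearest neighbour is compound 1, and the gap between them is a 10-fold higher number from compound 1 to compound 2 (1.00 log units; beyond the scatter), the change being chloro in place of (piperidin-4-yl)oxy on an aromatic carbon.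

Compound 3, `COc1cc(-c2cccnc2)ccc1C(N)=O`, is not yet measured. It differs from compound 2 by methoxy in place of chloro on an aromatic carbon. Among the measured compounds shown here, only one measured step touches this position: a 10-fold higher number from compound 1 to compound 2 (1.00 log units; beyond the scatter), which was beyond the scatter and went toward weaker inhibition when the (piperidin-4-yl)oxy group gave way to chloro. Methoxy carries the oxygen of that group but not the piperidine, so no measured step answers the question directly, and the expectation rests on the one step alone.

For the measured compounds named here, because the only comparable step is a 10-fold higher number from compound 1 to compound 2 (1.00 log units; beyond the scatter), a move back toward stronger inhibition is expected for compound 3, of size a 2.2-fold lower number from compound 2 to compound 3 (0.34 log units; beyond the scatter), smaller than the full return to compound 1. Compound 3 is estimated at 5000 nM, with a range of 1500 nM to 20000 nM.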

Compound 3, half-maximal inhibitory concentration: 2800 nM
Compound 3: middle estimate off by 1.8-fold (0.25 log units), on the high side; the measured number falls inside the stated range.
By their numbers in this assay, from the lowest: compound 1; then compound 3; then compound 2.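

In this assay, the position ortho to the carbamoyl group responds to a change of group even with no piperidine present: methoxy in place of chloro gives a gain in inhibition (a 3.9-fold lower number from compound 2 to compound 3 (0.59 log units; beyond the scatter)), so part of the loss seen with chloro is recovered by a small ether alone. The piperidine ring still counts, however, as methyl in place of piperidin-4-yl on the same oxygen goes toward weaker inhibition (a 2.5-fold higher number from compound 1 to compound 3 (0.41 log units; beyond the scatter)), which places methoxy between chloro and (piperidin-4-yl)oxy, with both steps beyond the scatter. No measurement at hand gives a reason for either step.

Still open, from the compounds shown here alone, is what in the piperidin-4-yl group carries the remaining gain: cyclohexyloxy, with no ring nitrogen, would separate the carbon ring from the amine, and a short aminoethoxy chain would test the amine without the ring. Also open, going by these compounds, is whether the ether oxygen matters in itself, which a plain ethyl group or a piperidin-4-yl group attached directly to the aromatic carbon would address.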